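Fluoro for ethyl on a scaffold without measured cytotoxicity

The source may hold more compounds than are shown below. What is called first, only, known or untested is meant among the compounds shown, and "the series" means these compounds.

Compound 1, `Cc1ccn2c(CCCCO)c(Cn3c(=O)n(C4CC4)c4ccncc43)nc2c1`: in an ADME assay on HEp-2 cells (Homo sapiens) for cytotoxicity, read by CCK-8 assay, with a stated time of 6 days (on this read-out lower numbers stand for higher toxicity in this test and higher numbers for lower toxicity in this test), compound 1 gives > 100000 nM, which is a limit of the assay.
Compound 2, `CCc1ccn2c(CCCCO)c(Cn3c(=O)n(C4CC4)c4ccncc43)nc2c1`: in this assay compound 2 gives > 100000 nM, also a limit of the assay.

Compound 2 therefore stands only at a limit, and both measured values sit together at the limit of > 100000 nM in this assay, at which 2 of the 2 values shown sit. For the measured compounds named here, the one measured step, a step that the two limits leave unreadable from compound 1 to compound 2, is methyl in place of hydrogen on a saturated chain carbon bound to an aromatic carbon, and the two limits leave its size unreadable.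

Compound 3, `O=c1n(Cc2nc3cc(F)ccn3c2CCCCO)c2cnccc2n1C1CC1`, differs from compound 2 by fluoro in place of ethyl on an aromatic carbon. Going by the values given here, no measured step shows a readable size, so no step beyond the scatter can be expected from it. Compound 3 is estimated in this assay at 100000 nM, in the range 30000 nM to 300000 nM, and the expected step of a number no higher from compound 2 to compound 3 (the limit leaves the size open) is none beyond the scatter.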

Compound 3, half-maximal cytotoxic concentration: > 100000 nM
Compound 3: no number, only a limit; the forecaster's own chance of this, stated with the estimate: 85%; the middle value sits exactly at the limit.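

In this assay compound 3 gives > 100000 nM as a limit of the assay, so no new step can be read between it and compound 1 or compound 2. The compounds shown leave open at what concentration any of them would turn cytotoxic, and whether fluoro, methyl or ethyl makes any difference.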